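Removing a Methyl From a Small Acidic NOTUM Fragment

The compounds below may be only part of what the source reports. "The series", "measured", "known", "first", "only" and "open" are said of these compounds alone.

Measured compounds: compound 1 `Cc1[nH]c(C(F)(F)F)cc1C(=O)O` with 6700 nM and compound 2 `O=C(O)C1CCN(c2ccccc2Cl)C1` with 19000 nM.

In an assay on cells for inhibition of Palmitoleoyl-protein carboxylesterase NOTUM variant C330S (Homo sapiens), read by fluorescence, with a stated time of 40 min (a lower number here means a stronger inhibitor, a higher number a weaker inhibitor), compound 1 gives 6700 nM, the lowest of the two numbers, while compound 2 gives 19000 nM, a gap beyond the scatter. Compound 3 `O=C(O)c1c[nH]c(C(F)(F)F)c1` differs from compound 1 by hydrogen in place of methyl on an aromatic carbon. For the measured compounds named here, with no measured pair of this kind to lean on, the step is expected to be modest and towards a weaker inhibitor. For compound 3 the estimate is 12000 nM (range 4000 nM to 40000 nM), which means an expected step of a 1.8-fold higher number from compound 1 to compound 3 (0.25 log units; within the scatter) in this assay.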

Compound 3, half-maximal inhibitory concentration: > 100000 nM
Compound 3: a limit, no number (the forecaster's own chance of this, stated with the estimate: 15%); at least 8.3-fold (0.92 log units) between middle value and limit.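

Hydrogen in place of methyl on this aromatic carbon, next to the ring nitrogen, gives an at least 14-fold higher number from compound 1 to compound 3 (1.17 log units; beyond the scatter) in this assay and so shows that this one small group weighs heavily in the activity of compound 1. The earlier compounds shown here offered no measured change at this position. For compound 3 the read-out is a limit of the assay and not a number: the limit of > 100000 nM in this assay, at which 1 of the 3 values shown sits.

From the compounds shown here alone, the full size of this step stays open. So does whether an ethyl group, a chlorine atom or an amine on this carbon would keep the activity of compound 1.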